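Ethyl in Place of Vinyl: An Expectation at the Limit

The source may report more compounds than this note shows. Statements on the series, on what has been measured and on what is new or still open speak of the compounds shown alone.

compound 1 `C=Cc1ccc(S(=O)(=O)Nc2ccc3oc(-c4ccccc4)nc3c2)cc1` gives > 63000 nM, a limit of the assay
compound 2 `C=Cc1ccc(S(=O)(=O)Nc2ccc(-c3nc4ccccc4o3)cc2)cc1` gives > 63000 nM, a limit of the assay
compound 3 `COc1ccccc1S(=O)(=O)Nc1ccc(-c2nc3ccccc3o2)cc1` gives > 63000 nM, a limit of the assay

In an assay on isolated protein for inhibition of malate dehydrogenase, mitochondrial (Sus scrofa), with stated times of 45 min and 30 min (a higher number here means a weaker inhibitor, a lower number a stronger inhibitor), compound 1 reaches only > 63000 nM, which is a limit of the assay and not a number. Compound 2 likewise stops at its limit of > 63000 nM. Compound 3 also stops at its limit of > 63000 nM. Among the measured compounds shown here, because all three sit at the limit of > 63000 nM in this assay, at which 3 of the 3 values shown sit, no ranking among them can be read, and the one step between measured compounds, a step that the two limits leave unreadable from compound 2 to compound 3, has no readable size.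

Compound 4 `CCc1ccc(S(=O)(=O)Nc2ccc3oc(-c4ccccc4)nc3c2)cc1` is the next compound to be tested. It differs from compound 1 by ethyl in place of vinyl on an aromatic carbon. For the measured compounds named here, no measured step bears on this change, and the only recorded step, a step that the two limits leave unreadable from compound 2 to compound 3, concerns a different change and is itself unreadable. With compound 1 at the limit and nothing pointing to a stronger inhibitor, compound 4 is expected to remain at the limit as well, with an estimated value of 100000 nM, between 40000 nM and 400000 nM. The step from compound 1 is thus expected to be a step that the limit leaves unreadable from compound 1 to compound 4, nothing beyond the scatter.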

Compound 4, half-maximal inhibitory concentration: > 63000 nM
Compound 4 was reported as a limit; the forecaster's own chance of this, stated with the estimate: 90%; the middle value does not contradict the limit.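

Compound 1 and compound 4 both stop at a limit of the assay, so ethyl in place of vinyl gives no new step that can be read: the limit of > 63000 nM in this assay, at which 4 of the 4 values shown sit.

The compounds shown leave open which structural change, if any, would bring a measurable value in this assay.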